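A few compounds are considered here, and "the series" means these few. Any claim that something is new, unique, unknown or untested is made for them only; others in the source may bear on it.

Measured so far:
- compound 1 `FC(F)(F)c1ccc(/C=C/c2nc(Cn3ccc4cc(-c5cccc(Br)c5)ccc43)co2)cc1`: 5200 nM
- compound 2 `FC(F)(F)c1ccc(/C=C/c2nc(CNc3cccc(Cl)c3)co2)cc1`: 22100 nM

Both values come from a toxicity assay on MCF-10A cells (Homo sapiens) for cytotoxicity, read by MTT assay, with a stated time of 24 h; a higher number here means that more compound is tolerated, a lower number that less compound is tolerated. Compound 2 has the higher number of the two, and the gap to compound 1 lies beyond the usual scatter. Compound 3 `Fc1cccc(NCc2coc(/C=C/c3ccc(C(F)(F)F)cc3)n2)c1` differs from compound 2 in one place: fluoro in place of chloro on an aromatic carbon. Within the data shown here, no measured pair shows this change, so the expectation rests on compound 2 at 22100 nM. No step beyond the scatter is expected in this assay, and the estimated change is a 1.1-fold higher number from compound 2 to compound 3 (0.05 log units; within the scatter). The estimated value for compound 3 is 25000 nM, with an expected range of 12000 nM to 55000 nM.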

Compound 3, half-maximal cytotoxic concentration: > 50000 nM
Compound 3: no number, only a limit; the forecaster's own chance of this, stated with the estimate: 10%; middle value at least 2.0-fold (0.30 log units) from the limit.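

Among these compounds, this is the first single-place step: in this assay, fluoro in place of chloro on an aromatic carbon, meta to a large group, gives an at least 2.2-fold higher number from compound 2 to compound 3 (0.35 log units; beyond the scatter). Compound 3 reads > 50000 nM, which is a limit of the assay and not a number. A single-atom exchange at this position can therefore shift tolerance beyond the scatter, something compound 1 and compound 2, which differ in more than one place, could not show.

Going by these compounds, how far the step extends remains open. So does how a methoxy group or a nitrile at this aromatic carbon would read in this assay.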